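A few compounds are considered here, and "the series" means these few. Any claim that something is new, unique, unknown or untested is made for them only; others in the source may bear on it.

Among the measured compounds shown here, compound 3 `O=C1C=CC2(C=C1)OCC(=O)N2c1nc(-c2ccc(F)c3ccccc23)nn1-c1ccccc1` gives 320 nM in a functional assay on A549 cells (Homo sapiens) for antiproliferative activity, with a stated time of 5 days (on this read-out higher numbers stand for weaker inhibition and lower numbers for stronger inhibition), the highest of the three numbers measured so far. Compound 2 `O=C1C=CC2(C=C1)OCC(=O)N2c1nc(-c2cccc3ccccc23)nn1-c1ccccc1` gives 80 nM, and compound 1 `O=C1C=CC2(C=C1)OCC(=O)N2c1nc(-c2ccc3ccccc3c2Br)nn1-c1ccccc1` gives 100 nM. Compound 4 `O=C1C=CC2(C=C1)OCC(=O)N2c1nc(-c2ccc3c(c2)OCCO3)nn1-c1ccccc1` differs from compound 3 in one place: 2,3-dihydro-1,4-benzodioxin-6-yl in place of 4-fluoronaphthalen-1-yl on an aromatic carbon. For the measured compounds named here, no measured step brings in this new group, so none bears directly on the change. The nearest guides are a 4.0-fold higher number from compound 2 to compound 3 (0.60 log units; beyond the scatter) and a 3.2-fold higher number from compound 1 to compound 3 (0.51 log units; beyond the scatter), which show that changes at this aromatic carbon shift the number modestly rather than sharply. Because compound 2 sits at 80 nM without the fluorine, a drift back toward the lower numbers is expected, with wide uncertainty. Compound 4 is therefore expected to give 200 nM, with a range from 60 nM to 700 nM, which would be a 1.6-fold lower number from compound 3 to compound 4 (0.20 log units; within the scatter).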

Compound 4, half-maximal inhibitory concentration: 170 nM
Compound 4: middle estimate off by 1.2-fold (0.07 log units), on the high side; low and high end bracket the measured number.
By their numbers in this assay, from the lowest: compounds 2, 1, 4 and 3 (each within the scatter of the next, the first and the last beyond it).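

The earlier compounds shown here all carried two aromatic rings of carbon only at this position, and in this assay compound 4 shows that a second such ring is not needed to keep a number in this range. Its 2,3-dihydro-1,4-benzodioxin-6-yl group gives steps within the scatter (a 1.9-fold lower number from compound 3 to compound 4 (0.27 log units; within the scatter); a 1.7-fold higher number from compound 1 to compound 4 (0.23 log units; within the scatter)), and only the comparison with naphthalen-1-yl goes beyond it (a 2.1-fold higher number from compound 2 to compound 4 (0.33 log units; beyond the scatter)). Nothing measured here explains these differences.

Going by these compounds, how an amine or a carboxylic acid would behave on this aromatic carbon remains open. So does the result of a 3,4-dimethoxyphenyl group, which would keep both oxygens without the non-aromatic ring.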